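Swapping phenyl for tert-butyl on a ketone of compound 1

The compounds below may be only part of what the source reports. "The series", "measured", "known", "first", "only" and "open" are said of these compounds alone.

Of the compounds shown here, three have been tested in an assay for displacement of a labelled ligand from adenosine receptor A1 (Bos taurus), tested at 10 uM; on this read-out lower numbers stand for less inhibition and higher numbers for more inhibition at the one concentration tested (going by the name of the read-out). Compound 1, `O=C1CCCc2[nH]c(=O)c(C(=O)c3ccccc3)cc21`, gives 6%. Compound 2, `O=C1CCCc2[nH]c(=O)c(S(=O)(=O)c3ccccc3)cc21`, gives 10%, and compound 3, `CC(=O)c1cc(C(=O)C(C)(C)C)c(=O)[nH]c1C`, gives 0%; these three numbers all lie within the usual scatter of one another, so none of them can be called stronger or weaker than the others on this evidence.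

The new compound 4, `CC(C)(C)C(=O)c1cc2c([nH]c1=O)CCCC2=O`, differs from compound 1 in one place: tert-butyl in place of phenyl on a carbonyl carbon. Among the compounds with values here, no measured pair shows this change directly. Since compound 3 also carries a tert-butyl group on a carbonyl carbon and gives 0%, the step is expected to stay within the scatter, with no direction beyond it, a number 2 percentage points lower from compound 1 to compound 4 (within the scatter). Compound 4 is therefore estimated at 4%, in a range from -5% to 14%.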

Compound 4, a percentage reported as inhibition, at one concentration (the size of the read-out at that concentration, not a potency): 13%
The estimate for compound 4 lay 9 percentage points below the measured number; the measured number falls inside the stated range.
By their numbers in this assay, from the lowest: compounds 3, 1, 2 and 4 (each within the scatter of the next, the first and the last beyond it).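

In this assay, the direct pair gives a number 7 percentage points higher from compound 1 to compound 4 (within the scatter) for tert-butyl in place of phenyl on a carbonyl carbon. Within the data shown here, this is the first direct reading of this change on the shared core, and it shows that losing the aromatic ring here moves the number no further than the scatter. Nothing measured here gives a reason for this result.

As far as these compounds go, whether a longer chain or an amine at this place would move the number beyond the scatter stays open. So does the effect of a carboxylic acid on the same carbonyl carbon.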